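The source may hold more compounds than are shown below. What is called first, only, known or untested is meant among the compounds shown, and "the series" means these compounds.

Measured in a physicochemical assay for lipophilicity; on this read-out higher numbers stand for higher lipophilicity and lower numbers for lower lipophilicity:
- Compound 1 `CC(=O)Nc1ccc2[nH]c(C)nc2c1`: 0.61
- Compound 2 `Cc1ccc2[nH]c(C)nc2c1`: 1.94

Of the two measured compounds, compound 2 stands highest at 1.94, and compound 1 lies lower at 0.61. The next compound, compound 3 `CCc1nc2cc(C)ccc2[nH]1`, carries one change from compound 2: methyl in place of hydrogen on a saturated chain carbon bound to an aromatic carbon. This is methyl in place of hydrogen on a saturated chain carbon bound to an aromatic carbon, which also reads as methyl to ethyl.

For the measured compounds named here, the only measured step is a number 1.33 log units higher from compound 1 to compound 2 (beyond the scatter), with methyl in place of acetamido on an aromatic carbon. Going by the values given here, that is a different change at a different place, so it bears only loosely on this one, and no measured step shows the new change directly. A moderate rise, smaller than that measured step, is expected in this assay, and the estimated change is a number 0.51 log units higher from compound 2 to compound 3 (beyond the scatter). For compound 3 the expected value is 2.45, with an estimated range of 2.15 to 2.8.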

Compound 3, partition coefficient: 2.44
Compound 3: the middle estimate sits 0.01 log units above what was measured; measured number inside the range.
By their numbers in this assay, from the lowest: compound 1; then compound 2; then compound 3.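

For the compounds shown here, at the saturated chain carbon bound to an aromatic carbon, methyl to ethyl reads in this assay as a number 0.50 log units higher from compound 2 to compound 3 (beyond the scatter) and is the first measured step at this place. The earlier compounds shown here offered only a number 1.33 log units higher from compound 1 to compound 2 (beyond the scatter) on an aromatic carbon with methyl in place of acetamido, a large step at another place, whereas this one is modest and shows that a single added methyl on the chain still moves the number beyond the scatter. Nothing at hand explains the size of this step.

On these data alone, whether a longer chain such as propyl, or a branched one such as isopropyl, would carry the number further remains open. Also open, as far as these compounds go, is how an amine or a carboxylic acid at this place would read in this assay and whether methyl to ethyl would give a like step on the core of compound 1.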